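The source may report more compounds than this note shows. Statements on the series, on what has been measured and on what is new or still open speak of the compounds shown alone.

In a functional assay on MCF7 cells (Homo sapiens) for inhibition, read by MTT assay, with a stated time of 72 h, tested at 10 uM (a lower number here means less inhibition, a higher number more inhibition at the concentration tested (going by the name of the read-out)), compound 1 `CCOC(=O)C1=C(Nc2ccccc2)S/C(=C\c2ccc([N+](=O)[O-])c(O)c2)C1=O` gives 41.5% and compound 2 `CCOC(=O)C1=C(Nc2ccccc2)S/C(=C\c2ccc(Br)c(O)c2)C1=O` gives 16.4%, the step being a number 25.1 percentage points lower from compound 1 to compound 2 (beyond the scatter). Compound 3 `CCOC(=O)C1=C(Nc2ccccc2Br)S/C(=C\c2ccc[nH]2)C1=O` gives 29.4%. Compound 2 thus holds the lowest of the three numbers, with compound 3 nearest and compound 1 furthest, both beyond the scatter. Compound 4 `CCOC(=O)C1=C(Nc2ccccc2)S/C(=C\c2cc[nH]c2)C1=O` follows from compound 2 by 1H-pyrrol-3-yl in place of 4-bromo-3-hydroxyphenyl on a double-bonded chain carbon bound to a double-bonded ring carbon. Within the data shown here, no measured step tracks this change: the one step in hand concerns bromo against nitro, and compound 3, which bears a five-membered aromatic ring with 1 hetero atom at that place, differs from compound 2 in a second place as well, so the two values are read only side by side. The expected step is a number 8.6 percentage points higher from compound 2 to compound 4 (within the scatter), upward but uncertain. Compound 4 is estimated at 25%, between 8% and 42%.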

Compound 4, a percentage reported as inhibition, at one concentration (the size of the read-out at that concentration, not a potency): < 10%
Compound 4 gave a limit, no number (the forecaster's own chance of this, stated with the estimate: 0%); middle value at least 15 percentage points away from the limit.
By their numbers in this assay, from the lowest: compound 2; then compound 3; then compound 1. At a limit, below all of these: compound 4.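

Compound 4 gives < 10% in this assay, a limit and not a number: the limit of < 10% in this assay, at which 1 of the 4 values shown sits.

Earlier steps touched only one substituent on the phenyl ring, whereas this one replaces the whole group, 1H-pyrrol-3-yl in place of 4-bromo-3-hydroxyphenyl, and reads as a number at least 6.4 percentage points lower from compound 2 to compound 4 (that floor lies within the scatter). The true size of this step stays unresolved.

Open, on these data alone, is whether the bromo or the hydroxy on the phenyl ring matters more for the read-out. Also open, as far as these compounds go, is how an amine or a carboxylic acid would read in place of the bromo.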